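Amine replacement on the shared core: compound 3 expected

The compounds below may be only part of what the source reports. "The series", "measured", "known", "first", "only" and "open" are said of these compounds alone.

Two compounds of the series carry the shared core. For compound 1 `O=C(NCc1ccc(F)cc1)c1nc(NCCO)c2cccnc2c1O` the entry in a functional assay on MCF7 cells (Homo sapiens) for cytotoxicity, read by MTT assay, with a stated time of 72 h (on this read-out higher numbers stand for weaker inhibition and lower numbers for stronger inhibition), reads "not determined" (no result reported), with no number behind it. Among the compounds with values here, compound 2 `Nc1ccc(Nc2c(C(=O)NCc3ccc(F)cc3)nc(Br)c3cccnc23)cc1` is therefore the only compound with a number: in this assay compound 2 gives 4000 nM, and it stands alone, with nothing else to rank it against. Within the data shown here, compound 3 `NCCCCCCNc1c(C(=O)NCc2ccc(F)cc2)nc(Br)c2cccnc12` differs from compound 2 in one place, (6-aminohexyl in place of 4-aminophenyl on a nitrogen on an aromatic ring), so the move between these two has no measured counterpart elsewhere. Among the measured compounds shown here, with a single anchor value and no comparable step to lean on, the expectation for compound 3 is a modest loss, and the step of a 1.5-fold higher number from compound 2 to compound 3 (0.18 log units; within the scatter) is what that estimate means, a change only slightly beyond the usual scatter. Compound 3 is expected to give 6000 nM in this assay, with a range from 1500 nM to 20000 nM.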

Compound 3, half-maximal inhibitory concentration: 2000 nM
Beside the measured number, compound 3's estimate is 3.0-fold (0.48 log units) above it, and the stated range covers the measured number.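

In this assay, 6-aminohexyl in place of 4-aminophenyl on a nitrogen on an aromatic ring gives a 2.0-fold lower number from compound 2 to compound 3 (0.30 log units; within the scatter) and stays within the scatter, so this pair cannot be told apart on this read-out. At this position, a measurable value therefore does not depend on the six-membered aromatic ring of 4-aminophenyl, as the ring-free 6-aminohexyl chain also gives one, although this rests on a single pair. Nothing at hand bears on why the two groups read alike.

Still open, on these data alone, is whether a shorter or longer chain between the ring nitrogen and the terminal amine would read differently in this assay. Replacing that terminal amine with a hydroxyl or a carboxylic acid is equally untested among the compounds shown, so its role at this position remains unknown.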